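Three Sulfonyl Compounds and an Indole Swap

This account rests on a few compounds, and the source may have more. Where it says the series, first, only, none or still open, it means among the compounds named here.

Measured in a functional assay on K562 cells (Homo sapiens) for inhibition, read by trypan blue exclusion, with a stated time of 72 h; a higher number here means a weaker inhibitor, a lower number a stronger inhibitor:
- Compound 1 `Cn1c(=O)c(S(=O)(=O)c2ccc(F)cc2F)cc2cnc(Nc3ccc4occc4c3)nc21`: 15000 nM
- Compound 2 `Cn1c(=O)c(S(=O)(=O)c2ccc(F)cc2F)cc2cnc(Nc3ccncn3)nc21`: 30000 nM
- Compound 3 `Cn1c(=O)c(S(=O)(=O)c2ccc(F)cc2F)cc2cnc(Nc3ccc4cccc(O)c4n3)nc21`: 5000 nM

Compound 3 has the lowest number of the three, so it is the strongest inhibitor measured so far. The gaps are modest: there is a 3.0-fold lower number from compound 1 to compound 3 (0.48 log units; beyond the scatter), and there is a 6.0-fold lower number from compound 2 to compound 3 (0.78 log units; beyond the scatter).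

Compound 4 `Cc1cc2cc(Nc3ncc4cc(S(=O)(=O)c5ccc(F)cc5F)c(=O)n(C)c4n3)ccc2[nH]1` shares the core of compound 3 but has not been measured. On a nitrogen on an aromatic ring, 2-methyl-1H-indol-5-yl stands in place of 8-hydroxyquinolin-2-yl: 2-methyl-1H-indol-5-yl in place of 8-hydroxyquinolin-2-yl on a nitrogen on an aromatic ring.

Both steps into compound 3 came from replacing another group with 8-hydroxyquinolin-2-yl, and both lowered the number. Among the measured compounds shown here, removing that group may therefore give some of this gain back, although no measured compound carries the new group. By name, the nearest measured group is the 1-benzofuran-5-yl of compound 1, which gives 15000 nM. The other exchange offers little guidance, with a 2.0-fold higher number from compound 1 to compound 2 (0.30 log units; within the scatter). A modest rise in this assay is therefore expected, and the estimated step is a 2.4-fold higher number from compound 3 to compound 4 (0.38 log units; beyond the scatter). Compound 4 is expected to give about 12000 nM, with an estimated range of 4000 nM to 30000 nM.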

Compound 4, half-maximal inhibitory concentration: 750 nM
For compound 4 the middle estimate is 16-fold (1.20 log units) above the measured one; the whole stated range lies above it.
By their numbers in this assay, from the lowest: compound 4; then compound 3; then compounds 1 and 2 (each within the scatter of the next).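

In this assay the group on this nitrogen proves able to do far more than the first three compounds suggested, since 2-methyl-1H-indol-5-yl gives a 6.7-fold lower number from compound 3 to compound 4 (0.82 log units; beyond the scatter) and so overtakes 8-hydroxyquinolin-2-yl, the best group until now. The wider steps are large, with a 40-fold lower number from compound 2 to compound 4 (1.60 log units; beyond the scatter) and a 20-fold lower number from compound 1 to compound 4 (1.30 log units; beyond the scatter) in the same assay, which makes compound 4 the strongest inhibitor of the four and shows that a change confined to this one group can shift the number substantially, even against 1-benzofuran-5-yl. Nothing shown here explains where this gain comes from.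

The compounds shown do not separate the share of the methyl from the share of the ring nitrogen with its hydrogen, and a plain 1H-indol-5-yl, a 1-methyl-1H-indol-5-yl or an ethyl in place of the methyl would each bear on that question. Going by these compounds, it also remains open whether the gain would hold with a carboxylic acid or an amine added to the indole group.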